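From furan-2-yl to iodo, starting at a limit

A few compounds are considered here, and "the series" means these few. Any claim that something is new, unique, unknown or untested is made for them only; others in the source may bear on it.

In a functional assay on CEM-DNR-bulk cells (Homo sapiens), read by MTT assay, with a stated time of 72 h (a lower number here means a stronger inhibitor, a higher number a weaker inhibitor), compound 1 `Cc1ncnc2c1c(-c1cc3ccccc3o1)cn2[C@@H]1O[C@H](CO)[C@@H](O)[C@H]1O` gives > 20000 nM, a limit of the assay and not a number. Compound 2 `Nc1nc(N)c2c(-c3ccco3)cn([C@@H]3O[C@H](CO)[C@@H](O)[C@H]3O)c2n1` gives > 20000 nM, also a limit. Compound 3 `Cc1nc(N)c2c(-c3ccco3)cn([C@@H]3O[C@H](CO)[C@@H](O)[C@H]3O)c2n1` gives > 20000 nM, again a limit. Every result so far therefore rests on (the limit of > 20000 nM in this assay, at which 3 of the 3 values shown sit). Compound 4 `Cc1nc(N)c2c(I)cn([C@@H]3O[C@H](CO)[C@@H](O)[C@H]3O)c2n1` has iodo in place of furan-2-yl on an aromatic carbon. Among the measured compounds shown here, the only measured step, a step that the two limits leave unreadable from compound 2 to compound 3, puts methyl in place of amino, so it offers no readable size to carry over. For the measured compounds named here, no measured step removes furan-2-yl, so the direction stays open. The expected change in this assay is no more than the scatter, with an estimated a number no higher from compound 3 to compound 4 (the limit leaves the size open). Compound 4 is estimated at 20000 nM, with an expected range of 4000 nM to 40000 nM.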

Compound 4, half-maximal inhibitory concentration: 3480 nM
For compound 4 the middle estimate is 5.7-fold (0.76 log units) above the measured one; the measured number lies below the stated range.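

In this assay, among the compounds shown here, the change on this aromatic carbon gives an at least 5.7-fold lower number from compound 3 to compound 4 (0.75 log units; beyond the scatter), so this position can move the read-out, which the earlier compounds did not show. For the compounds shown here, putting iodo in place of furan-2-yl yields the first value here that is a number and not a limit. The step's true size stays open because compound 3 rests on a limit: the limit of > 20000 nM in this assay, at which 3 of the 4 values shown sit.

Whether the gain comes from iodo itself or from losing furan-2-yl remains unclear; a bromo or ethynyl group on this carbon would help separate the two. As far as these compounds go, whether iodo would act the same with amino in place of methyl also stays open.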